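This account rests on a few compounds, and the source may have more. Where it says the series, first, only, none or still open, it means among the compounds named here.

Working notes on the sulfonamide series.

The series is followed in a functional assay on DLD-1 cells (Homo sapiens) for antiproliferative activity, read by CellTiter-Glo, with a stated time of 72 h; on this read-out higher numbers stand for weaker inhibition and lower numbers for stronger inhibition. Compound 1 `CC1CCN(C2CCN(S(=O)(=O)c3ccc(OCc4ccccc4)cc3)CC2)CC1` gives 385 nM in this assay. Compound 2 `Cc1cc(C)c(S(=O)(=O)N2CCN(C3CCN(C)CC3)CC2)c(C)c1` gives 426 nM, a number that sits within the scatter of the value of compound 1, so the two cannot be ranked against each other. Compound 3 `CC1CCN(C2CCN(S(=O)(=O)c3cccc(N)c3)CC2)CC1` gives 3400 nM, a number well beyond the scatter from compound 1 and from compound 2, so compound 3 stands apart as the weaker of the three on this read-out. No two of these compounds differ in a single place, so no measured step is available to guide the next move.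

Compound 4 `CC1CCN(C2CCN(S(=O)(=O)c3ccc(OC(F)(F)F)cc3)CC2)CC1` has not been measured. It differs from compound 1 in one place: trifluoromethyl in place of benzyl on an oxygen on an aromatic ring. The benzyl is lost, and the trifluoromethyl that enters brings no ring. There is no shown step on which to rest this change directly. Compound 3 shows that a small substituent on the aromatic ring of the sulfonyl group can sit far above compound 1, which points toward a higher number for compound 4. The step from compound 1 to compound 4 is expected to be a 2.2-fold higher number from compound 1 to compound 4 (0.34 log units; beyond the scatter), toward weaker inhibition, of moderate size. Compound 4 is expected to give about 850 nM, within a range from 280 nM to 2600 nM.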

Compound 4, half-maximal inhibitory concentration: 16 nM
The estimate for compound 4 lay 53-fold (1.73 log units) above the measured number; the whole stated range lies above it.
By their numbers in this assay, from the lowest: compound 4; then compounds 1 and 2 (each within the scatter of the next); then compound 3.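

In this assay, trifluoromethyl in place of benzyl on the oxygen gives a 24-fold lower number from compound 1 to compound 4 (1.38 log units; beyond the scatter). This shows that a low number at this position does not depend on the benzyl or its aromatic ring: on the core of compound 1, a group with no ring and fewer heavy atoms gives the lower number, and the change in this one place is enough to produce a large step. No measurement shown accounts for the size of this step, so it stands as an observation on this single pair.

The compounds shown leave open whether the lower number is specific to trifluoromethyl or would also appear with methyl, ethyl or a longer chain on the same oxygen. They also leave open how an amine or a carboxylic acid carried on that oxygen would read, and whether the same change would give a step of similar size on a core other than that of compound 1.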